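The source may hold more compounds than are shown below. What is called first, only, known or untested is meant among the compounds shown, and "the series" means these compounds.

Compound 2 `Cc1c(C(C)C)c(=O)on1C(=O)N1CCCCC1C` is the starting point of this account. In an assay (strain Wistar) for inhibition of Hormone-sensitive lipase (Rattus norvegicus), read by spectrophotometry (a lower number here means a stronger inhibitor, a higher number a weaker inhibitor), compound 2 gives 93 nM, the highest of the three numbers recorded. Compound 1 `Cc1c(C(C)C)c(=O)on1C(=O)N1CCCCC1` gives 2 nM in this assay, and the step of a 47-fold higher number from compound 1 to compound 2 (1.67 log units; beyond the scatter) is a large one. Among the measured compounds shown here, compound 3 `COCCc1c(C)n(C(=O)N2CCC(c3ccccc3)CC2)oc1=O` gives 11 nM in this assay, which is also lower than the number for compound 2, though no single-point step connects these two.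

Compound 4 `Cc1c(C(C)C)c(=O)on1C(=O)N1CC(C)CCC1C` differs from compound 2 by methyl in place of hydrogen on a saturated ring carbon. For the measured compounds named here, the only measured step that bears on this change is the one from compound 1 to compound 2, where the same kind of addition, a methyl in place of hydrogen on a saturated ring carbon, went with a 47-fold higher number from compound 1 to compound 2 (1.67 log units; beyond the scatter). A second methyl on the same ring is therefore expected to leave the number where it is or push it somewhat higher, not back down. Compound 4 is estimated at 200 nM in this assay, within a range from 50 nM to 800 nM, which would mean a step of a 2.2-fold higher number from compound 2 to compound 4 (0.33 log units; beyond the scatter).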

Compound 4, half-maximal inhibitory concentration: 460 nM
Compound 4: middle estimate off by 2.3-fold (0.36 log units), on the low side; the range from low to high includes it.
By their numbers in this assay, from the lowest: compound 1; then compound 3; then compound 2; then compound 4.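

In this assay, a methyl in place of hydrogen on a saturated ring carbon, two ring bonds from the ring nitrogen, goes with a 4.9-fold higher number from compound 2 to compound 4 (0.69 log units; beyond the scatter), so a second methyl on this ring raises the number further rather than restoring any of what was lost. This modest step is smaller than the large step seen with the first methyl, a 47-fold higher number from compound 1 to compound 2 (1.67 log units; beyond the scatter), so two methyl additions at different carbons of this ring do not carry the same weight. Nothing available accounts for the rise at either carbon.

The compounds shown leave open what this methyl does alone, on the unsubstituted ring of compound 1, without the first methyl present. They also leave open whether an ethyl, a hydroxyl or an amine at this ring carbon would go with a similar rise.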